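Pyridyl in Place of Carboxyphenyl: Compound 4 Expected Low

The compounds below may be only part of what the source reports. "The series", "measured", "known", "first", "only" and "open" are said of these compounds alone.

Compound 1 `CCOC(=O)C1=C(Nc2ccccc2)S/C(=C\c2ccc(O)c(O)c2)C1=O` gives 30.7% in a functional assay on A549 cells (Homo sapiens) for inhibition, read by MTT assay, with a stated time of 72 h, tested at 10 uM; on this read-out lower numbers stand for less inhibition and higher numbers for more inhibition at the one concentration tested (going by the name of the read-out). Compound 2 `CCOC(=O)C1=C(Nc2ccccc2)S/C(=C\c2ccc(C(=O)O)cc2)C1=O` gives 11.6% in this assay, the lowest of the two numbers shown, with compound 1 as its nearest neighbour. Compound 3 `CCOC(=O)C1=C(Nc2ccc(F)cc2)S/C(=C\c2ccc[nH]2)C1=O` in this assay gives only a limit, < 10%, and no number. Compound 4 `CCOC(=O)C1=C(Nc2ccccc2)S/C(=C\c2cccnc2)C1=O` has not yet been measured. It differs from compound 2 in one place: pyridin-3-yl in place of 4-carboxyphenyl on a double-bonded chain carbon bound to a double-bonded ring carbon. Among the compounds with values here, one measured step touches this place, a number 19.1 percentage points lower from compound 1 to compound 2 (beyond the scatter), a modest fall that left compound 2 where it stands. Compound 3, carrying yet another ring in that place, sits at the limit of < 10% in this assay, at which 1 of the 3 values shown sits. Within the data shown here, no measured compound carries the ring that compound 4 carries, so the evidence is indirect. Compound 4 is expected to stay in the low region, with an estimated step of a number 0.4 percentage points higher from compound 2 to compound 4 (within the scatter) that does not go beyond the scatter. Compound 4 is estimated at 12%, with a range from 0% to 30%.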

Compound 4, a percentage reported as inhibition, at one concentration (the size of the read-out at that concentration, not a potency): < 10%
Compound 4: only a limit was reported; the forecaster's own chance of this, stated with the estimate: 40%; middle value at least 2 percentage points from the limit.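

Compound 4 adds a second compound at the floor of the read-out in this assay, where its result is a limit and not a number: the limit of < 10% in this assay, at which 2 of the 4 values shown sit.

With pyridin-3-yl on the double-bonded chain carbon, the comparison with the 3,4-dihydroxyphenyl of compound 1 shows a number at least 20.7 percentage points lower from compound 1 to compound 4 (beyond the scatter), so this is now the second ring at this place, after 4-carboxyphenyl, to read beyond the scatter from compound 1. The exchange of 4-carboxyphenyl for pyridin-3-yl gives a number at least 1.6 percentage points lower from compound 2 to compound 4 (that floor lies within the scatter), so this step has no measured size and the two rings cannot be told apart here.

From the compounds shown here alone, whether a single hydroxyl on the phenyl ring would keep the reading of compound 1 stays open. So does the effect of a methoxy group in place of either hydroxyl.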